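The source may hold more compounds than are shown below. What is called first, only, known or untested is meant among the compounds shown, and "the series" means these compounds.

Compound 1, `CC(C)=CCOc1cc(Nc2nccc(CO)n2)ccc1Cl`: in an ADME assay on MT2 cells (Homo sapiens) for cytotoxicity (a lower number here means that less compound is tolerated, a higher number that more compound is tolerated), compound 1 gives 220 nM.
Compound 2, `Clc1ccc(Nc2ncccn2)cc1Oc1ccccc1`: compound 2 gives 30000 nM.
Compound 3, `COc1ccnc(Nc2ccc(Cl)c(Oc3ccccc3)c2)n1`: compound 3 gives 38000 nM.

Compound 3 has the highest of the three numbers. Going by the values given here, its nearest neighbour is compound 2, and the only single-place step among the measured compounds is a 1.3-fold higher number from compound 2 to compound 3 (0.10 log units; within the scatter), which lies within the scatter. Among the compounds with values here, compound 1 stands far lower, beyond the scatter, but it differs from compound 3 in more than one place, so no single step connects them.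

Compound 4, `COc1ccnc(Nc2ccc(Cl)c(Oc3cccc(C)c3)c2)n1`, differs from compound 3 by methyl in place of hydrogen on an aromatic carbon. Within the data shown here, none of the measured steps touches this change: the one measured step concerns methoxy in place of hydrogen on a different ring. With nothing to build on, the expectation is that compound 4 behaves like compound 3, with no step beyond the scatter. The expected value for compound 4 in this assay is therefore 38000 nM, between 19000 nM and 76000 nM. The step this expectation implies is no change at the digits printed from compound 3 to compound 4 (within the scatter).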

Compound 4, half-maximal cytotoxic concentration: 18000 nM
For compound 4 the middle estimate is 2.1-fold (0.32 log units) above the measured one; measured number outside the range, below it.
By their numbers in this assay, from the lowest: compound 1; then compounds 4, 2 and 3 (each within the scatter of the next, the first and the last beyond it).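

In this assay, the terminal phenoxy ring turns out to be a place where a single small addition can move the number: going from phenoxy to 3-methylphenoxy gives a 2.1-fold lower number from compound 3 to compound 4 (0.32 log units; beyond the scatter), so less of compound 4 is tolerated. Going by these compounds alone, the only earlier single-place step, a 1.3-fold higher number from compound 2 to compound 3 (0.10 log units; within the scatter), concerned methoxy on a different ring, so this is the first step to pass beyond the scatter, though only modestly. Nothing measured here explains why the methyl group has this effect.

It remains open whether this step is particular to methyl or would follow from other groups on this ring, since the compounds shown carry only this one addition there. An ethyl group, a fluorine, or an amine at the same place could show whether the number falls further or returns towards that of compound 3.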